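The compounds below may be only part of what the source reports. "The series", "measured", "known", "first", "only" and "open" are said of these compounds alone.

Compound 1 `c1ccc(OCc2nc3c(OCCCN4CCCCC4)cccc3n2CCCC2CCNCC2)cc1` gives 4.5 nM in an in vitro assay on AV12 cells for binding affinity to Neuropeptide Y receptor type 1 (Homo sapiens) (on this read-out higher numbers stand for weaker inhibition and lower numbers for stronger inhibition), the highest of the three numbers at hand. Compound 2 `CN1CCC(CCCn2c(COc3ccccc3)nc3c(OCCCN4CCCCC4)cccc32)CC1` gives 1.62 nM, and compound 3 `c1ccc(OCc2nc3c(OCCCN4CCCCC4)cccc3n2CCCC2CCN(CC3CCCCC3)CC2)cc1` gives 0.393 nM. Compound 4 `C(=C\c1ccccc1)\CN1CCC(CCCn2c(COc3ccccc3)nc3c(OCCCN4CCCCC4)cccc32)CC1` carries, relative to compound 1, 3-phenylprop-2-en-1-yl in place of hydrogen on an amine nitrogen in a ring and awaits measurement in this assay. Among the compounds with values here, two measured steps bear on this change at the same position: the step of a 2.8-fold lower number from compound 1 to compound 2 (0.44 log units; beyond the scatter), and the larger step of an 11-fold lower number from compound 1 to compound 3 (1.06 log units; beyond the scatter); between compounds 2 and 3 the step of a 4.1-fold lower number from compound 2 to compound 3 (0.62 log units; beyond the scatter) shows how much the extra ring added. Since 3-phenylprop-2-en-1-yl is a sizeable group like cyclohexylmethyl, a large step downward is expected for compound 4, roughly an 8.2-fold lower number from compound 1 to compound 4 (0.91 log units; beyond the scatter). The estimate for compound 4 in this assay is therefore 0.55 nM, within a range from 0.15 nM to 2 nM.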

Compound 4, inhibition constant: 0.183 nM
Beside the measured number, compound 4's estimate is 3.0-fold (0.48 log units) above it; measured number inside the range.
By their numbers in this assay, from the lowest: compound 4; then compound 3; then compound 2; then compound 1.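

In this assay, within the data shown here, the amine nitrogen in the ring allows more than the earlier compounds showed: 3-phenylprop-2-en-1-yl gives a 25-fold lower number from compound 1 to compound 4 (1.39 log units; beyond the scatter) as the largest step seen at this position. The unsaturated phenyl-bearing group also goes beyond the saturated ring, with a 2.1-fold lower number from compound 3 to compound 4 (0.33 log units; beyond the scatter) for 2-phenylethenyl in place of cyclohexyl and an 8.9-fold lower number from compound 2 to compound 4 (0.95 log units; beyond the scatter) for 2-phenylethenyl in place of hydrogen on the chain carbon. Nothing at hand accounts for these steps. Whether the gain depends on the double bond stays open, since 3-phenylpropyl is not among the compounds shown. Also open, from the compounds shown here alone, is what a shorter benzyl group or an amine on the phenyl ring would give.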